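Replacing a ring methyl with aryl groups on a shared core

The source may report more compounds than this note shows. Statements on the series, on what has been measured and on what is new or still open speak of the compounds shown alone.

Measured so far:
compound 1 `CN1CCN(CC(=O)Nc2nc3ccccc3[nH]2)CC1`: 33.5%
compound 2 `O=C(CN1CCN(c2ccccc2F)CC1)Nc1nc2ccccc2[nH]1`: 37.4%
compound 3 `O=C(CN1CCN(c2ccccn2)CC1)Nc1nc2ccccc2[nH]1`: 50%

All three were tested in a functional assay, read by spectrophotometry, with a stated time of 30 min, tested at 50 ug/mL; on this read-out lower numbers stand for a weaker effect and higher numbers for a stronger effect at the one concentration tested. Compound 1 gives the lowest number of the three: compound 2 lies a number 3.9 percentage points higher from compound 1 to compound 2 (within the scatter), and compound 3 lies a number 16.5 percentage points higher from compound 1 to compound 3 (beyond the scatter). Between the two aryl analogues, compound 3 lies a number 12.6 percentage points higher from compound 2 to compound 3 (beyond the scatter).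

Compound 4 `COc1ccccc1N1CCN(CC(=O)Nc2nc3ccccc3[nH]2)CC1` has not yet been measured. It differs from compound 1 in one place: 2-methoxyphenyl in place of methyl on an amine nitrogen in a ring.

Among the compounds with values here, two measured steps bear on this change, since both also put a six-membered aromatic ring on that same ring nitrogen in place of methyl. The step from compound 1 to compound 2, with a 2-fluorophenyl, stayed within the scatter. The step to compound 3, with a pyridin-2-yl, was modest and beyond the scatter. The 2-methoxyphenyl of compound 4 is, like 2-fluorophenyl, a ring of carbon only, so the closer guide is compound 2, whose value is 37.4%. Compound 4 is therefore expected to give a number 4.5 percentage points higher from compound 1 to compound 4 (within the scatter), most likely not beyond the scatter. The estimate for compound 4 in this assay is 38%, within a range from 26% to 52%.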

Compound 4, a percentage reported as activity, at one concentration (the size of the read-out at that concentration, not a potency): 35.7%
The estimate for compound 4 lay 2.3 percentage points above the measured number; the range from low to high includes it.
By their numbers in this assay, from the lowest: compounds 1, 4 and 2 (each within the scatter of the next); then compound 3.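

Exchanging methyl for the much larger 2-methoxyphenyl, which brings a six-membered aromatic ring of carbon only and a hydrogen-bond acceptor, barely registers in this assay (a number 2.2 percentage points higher from compound 1 to compound 4 (within the scatter)). Exchanging fluoro for methoxy on the aromatic carbon also makes no difference beyond the scatter (a number 1.7 percentage points lower from compound 2 to compound 4 (within the scatter)), so the two carbon-only aryl groups cannot be told apart from each other or from methyl at this ring nitrogen. Compound 3 goes against this flat picture (a number 14.3 percentage points lower from compound 3 to compound 4 (beyond the scatter)), which shows that an aromatic ring at this position does not by itself set the number and that pyridin-2-yl stands apart from 2-methoxyphenyl as well as from 2-fluorophenyl.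

From the compounds shown here alone, with one nitrogen-containing aromatic ring in the set, it remains open whether an unsubstituted phenyl or a pyrimidin-2-yl group on this ring nitrogen would give a number like that of compound 3 or like those of compound 2 and compound 4. The data shown offer no independent measurement that could explain the separate position of compound 3.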